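The source may hold more compounds than are shown below. What is called first, only, known or untested is meant among the compounds shown, and "the series" means these compounds.

Three compounds have been measured in an ADME assay on SK-OV-3 cells (Homo sapiens) for cytotoxicity, read by sulforhodamine B assay, with a stated time of 48 h, tested at 10 uM; on this read-out lower numbers stand for less inhibition and higher numbers for more inhibition at the one concentration tested (going by the name of the read-out):

Compound 1, `COc1nc2ccc(Br)cc2cc1C(c1ccccc1)n1cc(C2CC2)nn1`, gives 3.52%.
Compound 2, `COc1nc2ccc(Br)cc2cc1C(c1ccccc1)n1cc(-c2ccccc2F)nn1`, gives 7.33%.
Compound 3, `COc1nc2ccc(Br)cc2cc1C(c1ccccc1)n1cc(-c2cccc(F)c2)nn1`, gives 12.7%.

On these numbers compound 2 stands second highest of the three. Its nearest neighbour is compound 1, a number a number 3.8 percentage points higher from compound 1 to compound 2 (within the scatter); its furthest is compound 3, a number a number 5.4 percentage points higher from compound 2 to compound 3 (within the scatter). For the measured compounds named here, the whole spread of the set, from compound 1 to compound 3, is a number 9.2 percentage points higher from compound 1 to compound 3 (within the scatter), so no compound here separates from any other.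

The piece now follows the step from compound 2 to compound 4, `COc1nc2ccc(Br)cc2cc1C(c1ccccc1)n1cc(-c2ccc(OC(F)(F)F)cc2)nn1`. The change is 4-(trifluoromethoxy)phenyl in place of 2-fluorophenyl on an aromatic carbon

Going by the values given here, two measured steps bear on this one, as both exchange the group on the same aromatic carbon of the shared core. The step from compound 1 to compound 2 and the step from compound 2 to compound 3 were each within the scatter, and so was the larger step from compound 1 to compound 3. Among the compounds with values here, nothing among the measured compounds points to a move in this assay beyond the scatter in either direction, so the expected step is a number 1.7 percentage points higher from compound 2 to compound 4 (within the scatter). Compound 4 is therefore estimated to give 9% in this assay, within a range of 0% to 25%.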

Compound 4, a percentage reported as inhibition, at one concentration (the size of the read-out at that concentration, not a potency): 14.8%
The estimate for compound 4 lay 5.8 percentage points below the measured number; the range from low to high includes it.
By their numbers in this assay, from the lowest: compounds 1, 2, 3 and 4 (each within the scatter of the next, the first and the last beyond it).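

In this assay this aromatic carbon now shows its first step beyond the scatter, as 4-(trifluoromethoxy)phenyl in place of cyclopropyl gives a number 11.3 percentage points higher from compound 1 to compound 4 (beyond the scatter) and that step is modest. For the compounds shown here, the same group does not separate from either fluorophenyl group, with a number 7.5 percentage points higher from compound 2 to compound 4 (within the scatter) and a number 2.1 percentage points higher from compound 3 to compound 4 (within the scatter) both lying within the scatter, so the only pair of compounds that stands apart at this position is the pair at the two ends of the set, while compound 2 and compound 3 remain within the scatter of both. Nothing available gives a reason for this step.

The compounds shown leave open whether the step from cyclopropyl belongs to the trifluoromethoxy group or to the phenyl ring that carries it, and whether an amine, a carboxylic acid or a longer chain on that ring would move the number at all. All of these numbers also come from one concentration in one cell line, so they leave the potency of every compound unknown.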